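Triazole aryl swap: notes toward compound 4

The source may report more compounds than this note shows. Statements on the series, on what has been measured and on what is new or still open speak of the compounds shown alone.

Measured so far in a functional assay on A549 cells (Homo sapiens) for antiproliferative activity, read by MTT assay, with a stated time of 24 h; a higher number here means a weaker inhibitor, a lower number a stronger inhibitor:
compound 1, `Cc1ccc(-n2cc(-c3cccc(NS(=O)(=O)c4c[nH]c(=O)[nH]c4=O)c3)nn2)cc1`: 3630 nM
compound 2, `O=c1[nH]cc(S(=O)(=O)Nc2cccc(-c3cn(-c4ccccc4F)nn3)c2)c(=O)[nH]1`: > 20000 nM, a limit of the assay and not a number
compound 3, `Cc1ccc(-n2cc(-c3ccc(NS(=O)(=O)c4c[nH]c(=O)[nH]c4=O)cc3)nn2)cc1`: 5560 nM

Compound 1 and compound 3 are built from the same atoms joined differently; the difference between the two cores is not broken down here. In this assay compound 3 holds the higher of the two numbers given, with compound 1 nearest and within the scatter, so no order between compound 1 and compound 3 is claimed.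

From compound 1 to compound 2 the change is 2-fluorophenyl in place of 4-methylphenyl on an aromatic nitrogen. The step is an at least 5.5-fold higher number from compound 1 to compound 2 (0.74 log units; beyond the scatter). Compound 2 gives > 20000 nM, which is a limit of the assay and not a number. The size of that step is therefore known only as a lower bound, resting on (the limit of > 20000 nM in this assay, at which 1 of the 3 values shown sits).

Compound 4, `O=c1[nH]cc(S(=O)(=O)Nc2ccc(-c3cn(-c4ccccc4F)nn3)cc2)c(=O)[nH]1`, is not yet measured. It differs from compound 3 by 2-fluorophenyl in place of 4-methylphenyl on an aromatic nitrogen, the same change made at the same place as from compound 1 to compound 2. Since compound 3 already sits at a higher number than compound 1, the expected outcome for compound 4 is a step of about a 5.0-fold higher number from compound 3 to compound 4 (0.70 log units; beyond the scatter), resting on an at least 5.5-fold higher number from compound 1 to compound 2 (0.74 log units; beyond the scatter). Compound 4 is thus estimated at 28000 nM, between 10000 nM and 70000 nM, with a real chance that the assay reports only a limit.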

Compound 4, half-maximal inhibitory concentration: 5960 nM
Beside the measured number, compound 4's estimate is 4.7-fold (0.67 log units) above it, and the stated range ends above it.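

In this assay, 2-fluorophenyl in place of 4-methylphenyl on an aromatic nitrogen gives a 1.1-fold higher number from compound 3 to compound 4 (0.03 log units; within the scatter), so on this core the change leaves the number within the scatter. The change therefore does not carry over as a fixed step between the two cores: the same change on two cores in this assay, an at least 5.5-fold higher number (0.74 log units; beyond the scatter) from compound 1 to compound 2 and a 1.1-fold higher number (0.03 log units; within the scatter) from compound 3 to compound 4, at least 5.1-fold (0.71 log units) apart, beyond the scatter of two such steps. Compound 2 gives > 20000 nM, a limit of the assay and not a number, so the earlier step and the gap between the two steps are known only as lower bounds, and one pair on each of two cores gives no rule for any other core or any reason for the difference: the limit of > 20000 nM in this assay, at which 1 of the 4 values shown sits.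

On these data alone, only 4-methylphenyl and 2-fluorophenyl appear on the aromatic nitrogen, so it remains open whether the dependence on the core comes from the loss of the methyl group, the arrival of the fluorine, or both together, which 4-fluorophenyl and 2-methylphenyl on both cores would help to separate. Also open, as far as these compounds go, is whether the two cores diverge in the same way with an aryl group carrying an amine or a carboxylic acid, or with a longer chain in place of the aryl group.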